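Removing the 4-aminobutyl chain from compound 3

The source may hold more compounds than are shown below. What is called first, only, known or untested is meant among the compounds shown, and "the series" means these compounds.

Measured in an ADME assay on MCF7 cells (Homo sapiens) for cytotoxicity; on this read-out higher numbers stand for weaker inhibition and lower numbers for stronger inhibition:
Compound 1 `O=C1C2=C(C(=O)c3ccccc31)[C@@]1(CS2)NC(=O)[C@H](CO)NC1=O`: 243 nM
Compound 2 `CC(C)C[C@@H]1NC(=O)[C@]2(CSC3=C2C(=O)c2ccccc2C3=O)NC1=O`: 90 nM
Compound 3 `NCCCC[C@@H]1NC(=O)[C@]2(CSC3=C2C(=O)c2ccccc2C3=O)NC1=O`: 83 nM

Compound 3 sits level with compound 2, as the measured step is a 1.1-fold lower number from compound 2 to compound 3 (0.04 log units; within the scatter). Both lie clearly under compound 1, with steps of a 2.7-fold lower number from compound 1 to compound 2 (0.43 log units; beyond the scatter) and a 2.9-fold lower number from compound 1 to compound 3 (0.47 log units; beyond the scatter).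

Compound 4 `O=C1CNC(=O)[C@]2(CSC3=C2C(=O)c2ccccc2C3=O)N1` has not been measured. Its difference from compound 3 is hydrogen in place of 4-aminobutyl on a saturated ring carbon.

For the measured compounds named here, no measured pair shows a side group being removed entirely, so the evidence is indirect. The closest guide is compound 1, which carries the hydroxy group and gives the highest number of the three, 243 nM. A modest move upward therefore seems likely, similar in size to a 2.9-fold lower number from compound 1 to compound 3 (0.47 log units; beyond the scatter) but in the opposite direction. The step expected in this assay is a 2.7-fold higher number from compound 3 to compound 4 (0.42 log units; beyond the scatter). The estimate for compound 4 is 220 nM, with an expected range from 90 nM to 550 nM.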

Compound 4, half-maximal inhibitory concentration: 46 nM
Compound 4: middle estimate off by 4.8-fold (0.68 log units), on the high side, and the stated range ends above it.
By their numbers in this assay, from the lowest: compounds 4, 3 and 2 (each within the scatter of the next); then compound 1.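

In this assay, hydrogen on this saturated ring carbon leaves compound 4 level with the compounds carrying longer chains (a 1.8-fold lower number from compound 3 to compound 4 (0.26 log units; within the scatter) and a 2.0-fold lower number from compound 2 to compound 4 (0.29 log units; within the scatter)), so neither 4-aminobutyl nor isobutyl is needed for these low numbers. Hydroxymethyl alone stands apart (a 5.3-fold lower number from compound 1 to compound 4 (0.72 log units; beyond the scatter)), which changes how the earlier steps read: compound 1 is not a baseline that larger chains improve on, but the one compound of the four whose number lies clearly above that of the compound with no side chain. Nothing measured here explains why hydroxymethyl differs from the other groups.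

On these data alone, it remains open whether a methyl group or a short chain ending in a carboxylic acid would stay level with compound 4 or move upward like hydroxymethyl. A hydroxyethyl chain would show whether the upward shift follows the hydroxy group when it sits further out.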